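Adding a methyl to the core of compound 1

This account rests on a few compounds, and the source may have more. Where it says the series, first, only, none or still open, it means among the compounds named here.

Measured in a physicochemical assay for lipophilicity, at pH 7.4; on this read-out lower numbers stand for lower lipophilicity and higher numbers for higher lipophilicity:
- Compound 1 `Cc1cc(C)c(CN2CCc3ccc(O[C@@H]4CCOC4)c(Cl)c3C2=O)c(=O)[nH]1` gives 1.5
- Compound 2 `Cc1cc(C)c(CN2CCc3ccc(OC(C)C)c(Cl)c3C2=O)c(=O)[nH]1` gives 2.7

Compound 1 holds the lowest of these two numbers. For the measured compounds named here, the only measured step is a number 1.20 log units higher from compound 1 to compound 2 (beyond the scatter), a large change beyond the scatter, with isopropyl in place of oxolan-3-yl on an oxygen on an aromatic ring.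

Compound 3 `Cc1cc(C)c(CN2CCc3c(C)cc(O[C@@H]4CCOC4)c(Cl)c3C2=O)c(=O)[nH]1` keeps the oxolan-3-yl group and changes the core instead: methyl in place of hydrogen on an aromatic carbon. This is methyl in place of hydrogen on an aromatic carbon, para to a chloro group.

The measured step lies at another place, so it shows only that this read-out can move. Going by the values given here, no measured step covers this change. A small rise in this assay is expected, far short of the step to compound 2. The expected step is a number 0.40 log units higher from compound 1 to compound 3 (beyond the scatter). For compound 3 the estimated value is 1.9, with an expected range from 1.5 to 2.3.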

Compound 3, distribution coefficient: 2.1
Compound 3: middle estimate off by 0.20 log units, on the low side, and the stated range covers the measured number.
By their numbers in this assay, from the lowest: compound 1; then compound 3; then compound 2.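

For the compounds shown here, until now the only measured step in this assay lay at the group on the oxygen, and this result shows that the core can move the read-out as well. With the oxolan-3-yl group unchanged, methyl in place of hydrogen on an aromatic carbon, para to a chloro group, gives a number 0.60 log units higher from compound 1 to compound 3 (beyond the scatter) as a modest change from one added carbon. Nothing measured here accounts for the size of this step.

The compounds shown leave open how a fluoro group, an ethyl group or an amine on this same aromatic carbon would compare with methyl. They also leave open whether this methyl would give a step of similar size with isopropyl on the oxygen in place of oxolan-3-yl.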